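The source may report more compounds than this note shows. Statements on the series, on what has been measured and on what is new or still open speak of the compounds shown alone.

Compound 1 `CO[C@@H](C(=O)N[C@H]1CC[C@@H](O)CNC1=O)[C@H](O)[C@@H](O)[C@H](O)/C=C/C(C)(C)C`: > 150000 nM
Compound 2 `CO[C@@H](C(=O)N[C@H]1CCCCNC1=O)[C@@H]1OC(C)(C)O[C@H](/C=C/C(C)(C)C)[C@@H]1O`: > 150000 nM
Compound 3 `CO[C@@H](C(=O)N[C@@H]1CCCCNC1=O)[C@@H]1OC(C)(C)O[C@H](/C=C/C(C)(C)C)[C@@H]1O`: > 150000 nM

In a functional assay on HL-60 cells (Homo sapiens) for cytotoxicity, read by colorimetric assay and neutral red uptake, with a stated time of 72 h (on this read-out lower numbers stand for stronger inhibition and higher numbers for weaker inhibition), compound 1 gives > 150000 nM, which is a limit of the assay and not a number. In this assay compound 2 also gives > 150000 nM, again only a limit. Compound 3 gives > 150000 nM in this assay, a limit as well. Of the three values shown, none is a number, so compound 1 cannot be placed on a scale against the other two. Among the measured compounds shown here, the one measured step, a step that the two limits leave unreadable from compound 2 to compound 3, is a change of configuration alone, and it is the only step that bears on the move to compound 4 `CO[C@@H](C(=O)N[C@H]1CC[C@H](O)CNC1=O)[C@H](O)[C@@H](O)[C@H](O)/C=C/C(C)(C)C`. That move is the two compounds have the same atoms and bonds and differ only in configuration as drawn: 1 of 7 stereo elements differ; a stereocentre at a saturated ring carbon is drawn R in compound 1 and S in compound 4. Because the limit of > 150000 nM in this assay, at which 3 of the 3 values shown sit, and the fact that compounds 2 and 3 differ only in the configuration as drawn together, the size of the measured step stays hidden, and the drawn configuration of a saturated ring carbon is the sole thing changed. Compound 4 is therefore expected to give 300000 nM in this assay, within a range from 100000 nM to 1000000 nM. The estimated step that the limit leaves unreadable from compound 1 to compound 4 is expected to be none beyond the scatter, most likely returning a limit again.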

Compound 4, half-maximal inhibitory concentration: > 150000 nM
Compound 4 was reported as a limit; the forecaster's own chance of this, stated with the estimate: 90%; the middle value is on the limit's open side.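

In this assay compound 4 gives > 150000 nM, which is a limit of the assay and not a number. Compound 1 also stands at a limit, so no step can be read between compound 1 and compound 4. The compounds shown leave open whether the configuration drawn at a saturated ring carbon matters for cytotoxicity at all.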